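Swapping Fluoro for Cyano across Two Cores

The source may report more compounds than this note shows. Statements on the series, on what has been measured and on what is new or still open speak of the compounds shown alone.

Compound 1 `CCOC(=O)C(=O)CC(=O)/C=C/c1cn(Cc2ccc(F)cc2)c2ccccc12` and compound 2 `CCOC(=O)C(=O)CC(=O)/C=C/c1cn(Cc2ccc(C#N)cc2)c2ccccc12` share one core, while compound 3 `O=C(/C=C/c1cc(C(=O)c2ccccc2)cn1Cc1ccc(F)cc1)CC(=O)C(=O)O` and compound 4 `N#Cc1ccc(Cn2cc(C(=O)c3ccccc3)cc2/C=C/C(=O)CC(=O)C(=O)O)cc1` share another; the difference between the two cores is not broken down here. All of them belong to an assay on isolated protein for inhibition of DNA nucleotidylexotransferase (Homo sapiens), read by scintillation counting, with a stated time of 10 min; on this read-out lower numbers stand for stronger inhibition and higher numbers for weaker inhibition. Compound 1 reaches only the limit of > 40 uM in this assay. Compound 2 likewise gives only the limit > 40 uM in this assay. Among the measured compounds shown here, compound 3, in this assay, gives 9.5 uM, the single number among the three measured. The change from compound 1 to compound 2 is cyano in place of fluoro on an aromatic carbon, and the resulting step, a step that the two limits leave unreadable from compound 1 to compound 2, cannot be read because the limit of > 40 uM in this assay, at which 2 of the 3 values shown sit, covers both ends of it. The same change, (cyano in place of fluoro on an aromatic carbon), leads from compound 3 to compound 4. Because the earlier step is a step that the two limits leave unreadable from compound 1 to compound 2, the change is expected to leave the value of compound 3 near where it stands, with an estimated step of a 1.1-fold higher number from compound 3 to compound 4 (0.02 log units; within the scatter). Compound 4 is therefore estimated at 10 uM in this assay, most likely between 3 uM and 40 uM.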

Compound 4, concentration for 50% inhibition: 6.8 uM
The estimate for compound 4 lay 1.5-fold (0.17 log units) above the measured number, and the stated range covers the measured number.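

In this assay cyano in place of fluoro on an aromatic carbon gives a 1.4-fold lower number from compound 3 to compound 4 (0.15 log units; within the scatter) and so, in the core of compound 3, the 4-fluorobenzyl and 4-cyanobenzyl compounds cannot be told apart. This is one pair in one core, so it shows that the change can be made there without a step beyond the scatter, but it does not show that the change behaves alike in other cores of the series. The step in the core of compound 1 cannot be read, so no comparison of the change across the two cores is possible, because both ends of that step rest on an assay limit and not on a number: the limit of > 40 uM in this assay, at which 2 of the 4 values shown sit.

The compounds shown leave open how a group other than fluoro or cyano, such as an amine or a methoxy group, behaves at the same place on the ring. They also leave open whether a longer chain in place of the benzyl link keeps compound 3 and compound 4 within the scatter of each other.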